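A few compounds are considered here, and "the series" means these few. Any claim that something is new, unique, unknown or untested is made for them only; others in the source may bear on it.

Within the data shown here, only two compounds have numbers so far. In an ADME assay on microsomes from liver (Rattus norvegicus) for metabolic stability (a higher number here means that the compound lasts longer, a lower number that the compound disappears faster), compound 1 `COc1cc(OCc2cccc(-c3ccc(C#N)cn3)c2)c2cc(-c3cn4nc(OC)sc4n3)oc2c1` gives 0.833 h and compound 2 `COc1cc(OCc2csc(-c3ccccc3)n2)c2cc(-c3cn4nc(OC)sc4n3)oc2c1` gives 1.22 h and the two values lie within the scatter of each other. Among the measured compounds shown here, compound 1 therefore stands level with the only other measured compound. For the measured compounds named here, no pair of measured compounds differs in a single place, so the series offers no direct guide to the next change. Compound 3 `COc1cc(OCc2cccc(OCc3ccccc3)c2)c2cc(-c3cn4nc(OC)sc4n3)oc2c1` has benzyloxy in place of 5-cyanopyridin-2-yl on an aromatic carbon, meta to a large group, a swap counted as benzyloxy in place of 5-cyanopyridin-2-yl on an aromatic carbon against compound 1. The expected step in this assay is none beyond the scatter, estimated as a 1.2-fold lower number from compound 1 to compound 3 (0.08 log units; within the scatter) with only a slight lean towards faster disappearance. That expectation has just compound 1 at 0.833 h and compound 2 at 1.22 h as reference points. For compound 3 the estimated half-life is 0.7 h with an expected range from 0.3 h to 1.6 h as the likely span.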

Compound 3, half-life: 0.333 h
Compound 3: the middle estimate sits 2.1-fold (0.32 log units) above what was measured; measured number inside the range.
By their numbers in this assay, from the lowest: compound 3; then compounds 1 and 2 (each within the scatter of the next).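

In this assay, among these compounds, this position on the aromatic carbon is sensitive to the group it carries: benzyloxy in place of 5-cyanopyridin-2-yl gives a 2.5-fold lower number from compound 1 to compound 3 (0.40 log units; beyond the scatter), the only step so far that can be read across a single change. The two groups match in heavy atoms as counted, so that count does not separate them, although they differ in ring composition, the triple bond and hydrogen-bond acceptors. No available measurement bears on the reason for this step.

As far as these compounds go, it remains open which part of the exchange carries the step, since a plain phenyl or pyridin-2-yl group at this position would separate the ring from the nitrile. How an amine such as morpholine would behave at this position is also unknown.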